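The source may report more compounds than this note shows. Statements on the series, on what has been measured and on what is new or still open speak of the compounds shown alone.

Working notes on the series. The shared core, seen in compound 1 `CC(C)c1ccc(N2C(=O)C=CC2OCC(F)(F)F)cc1`, compound 2 `O=C1C=CC(OCC(F)(F)F)N1c1ccc(F)c(Cl)c1` and compound 3 `O=C1C=CC(OCC(F)(F)F)N1c1ccc(C(F)(F)F)cc1`, carries a trifluoroethoxy-bearing lactam on an aryl ring that differs only in its substituents. In a functional assay on A549 cells (Homo sapiens) for inhibition (a lower number here means a stronger inhibitor, a higher number a weaker inhibitor), compound 1 gives 9570 nM, compound 2 gives 7690 nM and compound 3 gives 8390 nM; the three numbers lie within the scatter of one another, so no order can be read among them.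

Compound 4 `O=C1C=CC(OCC(F)(F)F)N1c1ccc(Br)cc1` follows from compound 1 by one change: bromo in place of isopropyl on an aromatic carbon. The step that bears on this is the one at the same aromatic carbon, a 1.1-fold lower number from compound 1 to compound 3 (0.06 log units; within the scatter), which stayed within the scatter. Compound 2, with a different pattern of halogens, likewise gives a value within the scatter of compound 1. No variation at this position has yet moved this assay beyond the scatter, so for compound 4 no step beyond the scatter is expected, a 1.1-fold lower number from compound 1 to compound 4 (0.04 log units; within the scatter). Compound 4 is therefore estimated at 8800 nM in this assay, in the range 4000 nM to 19000 nM.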

Compound 4, half-maximal inhibitory concentration: 6960 nM
Compound 4: middle estimate off by 1.3-fold (0.10 log units), on the high side, within the range that was stated.
By their numbers in this assay, from the lowest: compounds 4, 2, 3 and 1 (each within the scatter of the next).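

A single bromo group now stands on this aromatic carbon in place of isopropyl, a change from 3 heavy atoms to 1 heavy atom, and in this assay the step is a 1.4-fold lower number from compound 1 to compound 4 (0.14 log units; within the scatter). Bromo in place of trifluoromethyl at the same carbon gives a 1.2-fold lower number from compound 3 to compound 4 (0.08 log units; within the scatter), so isopropyl, trifluoromethyl and bromo cannot be told apart here, and size of the group, over this span, shows no readable effect on the number. No measurement at hand offers an explanation for this.

From the compounds shown here alone, whether a group of another kind on this carbon, such as an amine or a carboxylic acid, would move the number beyond the scatter remains open. Also open, going by these compounds, is what a longer chain in place of the trifluoroethoxy group on the shared core would do in this assay.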